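Amide swap in a series sitting at the assay limit

The source may report more compounds than this note shows. Statements on the series, on what has been measured and on what is new or still open speak of the compounds shown alone.

Compound 1 `O=C(C1CCC(F)(F)CC1)N1CC(c2nc(-c3cccc(Cl)c3)no2)C1` in an assay on HEK293 cells for negative allosteric modulation of metabotropic glutamate receptor 5 (Homo sapiens), read by FLIPR (a lower number here means a stronger inhibitor, a higher number a weaker inhibitor), gives > 10000 nM, a limit and not a number.
Compound 2 `Cc1cccc(-c2noc(C3CN(C(=O)C4CCC(C(F)(F)F)CC4)C3)n2)c1` in this assay gives > 10000 nM, again a limit.
Compound 3 `O=C(c1ccc(F)c(F)c1)N1CC(c2nc(-c3cccc(F)c3)no2)C1` in this assay gives > 10000 nM, also a limit.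

Compound 1 therefore stands where every measured compound stands, at the limit of > 10000 nM in this assay, at which 3 of the 3 values shown sit; no ordering among the three is possible. Among the compounds with values here, no pair of measured compounds differs in one place, so no measured step is available.

Compound 4 `O=C(C1CCCO1)N1CC(c2nc(-c3cccc(Cl)c3)no2)C1` differs from compound 1 by oxolan-2-yl in place of 4,4-difluorocyclohexyl on a carbonyl carbon. With nothing in the measured set pointing to a gain, the step that the limit leaves unreadable from compound 1 to compound 4 is expected to be none beyond the scatter, and compound 4 is estimated at 15000 nM, between 5000 nM and 50000 nM, most likely reported only as a limit again.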

Compound 4, half-maximal inhibitory concentration: 890 nM
Compound 4: the middle estimate sits 17-fold (1.23 log units) above what was measured, outside the stated range (below it).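

On a carbonyl carbon bound to the ring amide-type nitrogen, oxolan-2-yl in place of 4,4-difluorocyclohexyl gives an at least 11-fold lower number from compound 1 to compound 4 (1.05 log units; beyond the scatter) in this assay. This position can therefore move the series off the assay limit, and compound 4 is the only compound shown with a readable value: the limit of > 10000 nM in this assay, at which 3 of the 4 values shown sit. Compound 1 remains a limit at > 10000 nM, so the step has no defined upper size.

The change alters ring size and adds a ring oxygen together, so this single pair cannot separate the two. A cyclopentyl or oxan-4-yl group on the same carbonyl carbon would bear on that question.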